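This account rests on a few compounds, and the source may have more. Where it says the series, first, only, none or still open, it means among the compounds named here.

Working notes on the series. In an ADME assay on microsomes from liver (Mus musculus) for metabolic stability, with a stated time of 10 min, tested at 1 uM (a lower number here means that less of the compound is left, a higher number that more of the compound is left), compound 1 `COc1c(-c2ccc(C(F)(F)F)cc2Cl)ccc2nn([C@@H](CC(C)C)c3ccc(C(=O)NCCC(=O)O)cc3)cc12` gives 82% and compound 2 `Cc1cc(C(F)(F)F)ccc1-c1ccc2nn([C@@H](CC(C)C)c3ccc(C(=O)NCCC(=O)O)cc3)cc2c1C` gives 50%. Compound 2 is the lower of the two measured compounds, and its gap to compound 1 lies beyond the usual scatter.

The next compound is compound 3 `Cc1c(-c2ccc(C(F)(F)F)cc2Cl)ccc2nn([C@@H](CC(C)C)c3ccc(C(=O)NCCC(=O)O)cc3)cc12`, which differs from compound 2 by one exchange (chloro in place of methyl on an aromatic carbon). This exchange turns 2-methyl-4-(trifluoromethyl)phenyl into 2-chloro-4-(trifluoromethyl)phenyl.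

Among the compounds with values here, no measured pair isolates this exchange, so the expectation rests only on the two values in hand and is weakly supported. A moderate upward move is expected in this assay, with the estimated step of a number 15 percentage points higher from compound 2 to compound 3 (beyond the scatter) as the working figure. The expected value for compound 3 is 65% (range 48% to 82%).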

Compound 3, percent of the compound remaining: 97%
The estimate for compound 3 lay 32 percentage points below the measured number, and the stated range ends below it.
By their numbers in this assay, from the lowest: compound 2; then compound 1; then compound 3.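

In this assay, with the methyl on the shared core held constant, chloro in place of methyl on the aromatic carbon ortho to a large group gives a number 47 percentage points higher from compound 2 to compound 3 (beyond the scatter), so the read-out responds strongly to this single exchange. With 2-chloro-4-(trifluoromethyl)phenyl held constant, methyl in place of methoxy on an aromatic carbon of the core gives a number 15 percentage points higher from compound 1 to compound 3 (beyond the scatter), a modest step, which separates two changes that compound 1 and compound 2 carried together. Nothing at hand speaks to the cause of either step.

Open, on these data alone, is whether fluoro or a nitrile in place of chloro would keep the number as high as in compound 3. Also open, as far as these compounds go, is whether the chloro gain carries over to the core bearing methoxy, or to an ethyl group on that carbon.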